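The source may hold more compounds than are shown below. What is called first, only, known or untested is meant among the compounds shown, and "the series" means these compounds.

Measured compounds: compound 1 `COc1cc(-c2cc(/C=C/C(=O)c3ccc(N)cc3)[nH]n2)cc(OC)c1OC`, compound 2 `COc1ccc(-c2cc(/C=C/C(=O)c3ccc(OC)c(OC)c3)[nH]n2)cc1`, compound 3 `COc1cc(-c2cc(/C=C/C(=O)c3ccc(Cl)c(Cl)c3)[nH]n2)cc(OC)c1OC`.

In a functional assay on SR cells (Homo sapiens) for cytotoxicity, read by sulforhodamine B assay, with a stated time of 48 h, tested at 0.01 uM (on this read-out lower numbers stand for a stronger effect and higher numbers for a weaker effect at the one concentration tested), compound 1 gives 92%, compound 2 gives 100% and compound 3 gives 104%. Compound 1 stands lowest of the three; its gap to compound 2 lies within the scatter, while its gap to compound 3 lies beyond it. Compound 4 `COc1ccc(-c2cc(/C=C/C(=O)c3ccc(N)cc3)[nH]n2)cc1OC` differs from compound 1 by hydrogen in place of methoxy on an aromatic carbon. Going by the values given here, the only measured step, a number 12 percentage points higher from compound 1 to compound 3 (beyond the scatter), concerns the group on the carbonyl carbon and so does not bear on this change. Compound 1 and compound 2 differ in two places, so their values alone cannot isolate the loss of one methoxy. No step beyond the scatter is therefore expected in this assay. Compound 4 is estimated at 95%, within 84% to 106%, which means an expected step of a number 3 percentage points higher from compound 1 to compound 4 (within the scatter).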

Compound 4, a percentage reported as activity, at one concentration (the size of the read-out at that concentration, not a potency): 98%
Compound 4: the middle estimate sits 3 percentage points below what was measured, within the range that was stated.
By their numbers in this assay, from the lowest: compounds 1, 4, 2 and 3 (each within the scatter of the next, the first and the last beyond it).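

In this assay, hydrogen in place of methoxy on an aromatic carbon gives a number 6 percentage points higher from compound 1 to compound 4 (within the scatter). Going by these compounds alone, this is the first single change at this position, ortho to a methoxy group, and it produces no step beyond the scatter at the one concentration tested, whereas the earlier single step concerned only the group on the carbonyl carbon. Nothing at hand explains this result. Going by these compounds, whether a hydroxy group, an ethoxy group or a fluorine atom at this position would read the same remains open. So does whether the loss of this methoxy would matter on a different group at the carbonyl carbon.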